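Pyridylmethyl ether in place of biphenylmethyl ether

The compounds below may be only part of what the source reports. "The series", "measured", "known", "first", "only" and "open" are said of these compounds alone.

Of the compounds shown here, three sharing one acid core have been tested in an assay on isolated protein for inhibition of Polyunsaturated fatty acid 5-lipoxygenase (Homo sapiens), read by HPLC, with a stated time of 15 min; on this read-out lower numbers stand for stronger inhibition and higher numbers for weaker inhibition. Compound 1 `CCCC/C(=C\c1cc(Oc2ccccc2)ccc1OCc1ccc(C(F)(F)F)cc1)C(=O)O` carries a phenoxy group and gives 2100 nM. Compound 2 `CCCC/C(=C\c1cc(OCc2ccc(CCCC)cc2)ccc1OCc1ccc(C(F)(F)F)cc1)C(=O)O` carries a butylbenzyl ether at the same position, and for compound 2 the result is "not active" (no number reported). Compound 3 `CCCC/C(=C\c1cc(OCc2ccc(-c3ccccc3)cc2)ccc1OCc1ccc(C(F)(F)F)cc1)C(=O)O` carries a biphenylmethyl ether, and for compound 3 the result is likewise "not active" (no number reported). Compound 3 therefore stands without a number, as does compound 2, and only compound 1 has a measured concentration.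

Compound 4 `CCCC/C(=C\c1cc(OCc2cccnc2)ccc1OCc1ccc(C(F)(F)F)cc1)C(=O)O` is the next member. The change from compound 3 to compound 4 is pyridin-3-yl in place of 4-phenylphenyl on a saturated chain carbon bound to an oxygen on an aromatic ring. Within the data shown here, no measured step between two numbered compounds is available for this change, so no direction can be read from the data. What the measured compounds show is that the smallest ether, in compound 1, gave a number, while the two larger benzyl ethers gave none. Compound 4 sits between these in size of the appended ring group. Compound 4 is expected to be weak in this assay, with an estimate of 6000 nM and a range from 1500 nM to 30000 nM, and a considerable chance that, like compound 3, only an inactive result is reported.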

Compound 4, half-maximal inhibitory concentration: 2300 nM
Beside the measured number, compound 4's estimate is 2.6-fold (0.42 log units) above it; low and high end bracket the measured number.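

In this assay, compound 4 gives 2300 nM, so an ether with a saturated chain carbon bound to the oxygen on the aromatic ring can still give a number at this position, although compound 2 and compound 3, which share that chain carbon, were reported only as not active. With pyridin-3-yl in place of 4-phenylphenyl, a result with no number becomes a measured one, but the size of this change cannot be read, and the values show a 1.1-fold higher number from compound 1 to compound 4 (0.04 log units; within the scatter), so (pyridin-3-yl)methyl and phenyl on this oxygen cannot be told apart in this test. No independent measurement is available to explain this result.

The group that enters differs from the one that leaves in two ways, with one aromatic ring instead of two and with a ring nitrogen, and the compounds shown do not separate these two differences. A plain phenyl on the same chain carbon would address the role of the nitrogen, while pyridin-2-yl and pyridin-4-yl would show whether the nitrogen's place in the ring matters.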